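The source may hold more compounds than are shown below. What is called first, only, known or untested is meant among the compounds shown, and "the series" means these compounds.

Working notes on the series. Compound 1 `Cc1cc(Cl)cc(C(=O)Nc2nn[nH]n2)n1` carries a chloro group, and in a functional assay on the whole organism for inhibition, with Rattus norvegicus as the target, at a dose of 10 mg/kg by the oral route (a lower number here means a weaker effect, a higher number a stronger effect of the compound at the dose given), compound 1 gives 100%. Compound 2 `Cc1cc([N+](=O)[O-])cc(C(=O)Nc2nn[nH]n2)n1` carries a nitro group in its place, and in this assay compound 2 gives 6%. For the measured compounds named here, the single measured step is a number 94 percentage points lower from compound 1 to compound 2 (beyond the scatter). Going by the values given here, compound 2 therefore stands lowest of the two numbers, with compound 1 as its only neighbour, well beyond the scatter above it. Compound 3 `COc1cc(C)nc(C(=O)Nc2nn[nH]n2)c1` is not yet measured; it differs from compound 2 by methoxy in place of nitro on an aromatic carbon. Among the compounds with values here, no measured compound carries a methoxy group, so the only step that bears on this change is the large chloro-to-nitro step, which shows that the group at that position can move the read-out across most of its range. Since compound 3 carries neither group, its number is expected to fall between the two, with a number 49 percentage points higher from compound 2 to compound 3 (beyond the scatter). The estimate for compound 3 in this assay is 55%, within 10% to 100%.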

Compound 3, a percentage reported as inhibition, in the whole organism at one dose (the size of the read-out at that dose, not a potency): 20%
Compound 3: middle estimate off by 35 percentage points, on the high side; low and high end bracket the measured number.
By their numbers in this assay, from the lowest: compound 2; then compound 3; then compound 1.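

In this assay, methoxy in place of nitro gives a number 14 percentage points higher from compound 2 to compound 3 (beyond the scatter), so moving away from nitro does not by itself restore the read-out, and methoxy stays far closer to nitro than to chloro. Methoxy in place of chloro gives a number 80 percentage points lower from compound 1 to compound 3 (beyond the scatter), which shows that the large drop is not confined to nitro: among the three groups at this place, opposite the ring nitrogen, chloro alone gives a high read-out at this dose. Nothing at hand bears on the cause of this result.

As far as these compounds go, it remains open whether the high read-out is particular to chloro or is shared by other halogens such as fluoro or bromo, and how an amine or a longer chain would behave at this place. A single dose also leaves open how these compounds would compare at other doses.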